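Cyano to carboxy on a shared core

A few compounds are considered here, and "the series" means these few. Any claim that something is new, unique, unknown or untested is made for them only; others in the source may bear on it.

Compound 3 `N#Cc1cccc2c1nc(-c1c(F)cccc1F)n2Cc1c(F)cccc1F` carries a cyano group on the aromatic ring of its core. In a toxicity assay on CCRF-CEM cells (Homo sapiens) for cytotoxicity (a lower number here means that less compound is tolerated, a higher number that more compound is tolerated), compound 3 gives 26.7 uM, the highest of the two numbers shown, though its nearest neighbour lies within the scatter: a 1.0-fold higher number from compound 2 to compound 3 (0.01 log units; within the scatter). That neighbour is compound 2 `Nc1cccc2c1nc(-c1c(F)cccc1F)n2Cc1c(F)cccc1F`, which in this assay gives 26.3 uM. Compound 1 `Cc1cccc2c1nc(-c1c(F)cccc1F)n2Cc1c(F)cccc1F` carries a methyl group instead; in this assay compound 1 reaches only a limit, > 100 uM. The reference point for that is the limit of > 100 uM in this assay, at which 1 of the 3 values shown sits. Measured against compound 1, both replacements lowered the number beyond the scatter: an at least 3.8-fold lower number from compound 1 to compound 2 (0.58 log units; beyond the scatter) and an at least 3.7-fold lower number from compound 1 to compound 3 (0.57 log units; beyond the scatter).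

Compound 4 `O=C(O)c1cccc2c1nc(-c1c(F)cccc1F)n2Cc1c(F)cccc1F` differs from compound 3 in one place: carboxy in place of cyano on an aromatic carbon. Among the measured compounds shown here, no measured step exchanges cyano for carboxy, so the bearing steps are the two from compound 1, both at least modest and downward, and the one from compound 2 to compound 3, which stayed within the scatter. Since the exchange of amino for cyano did not move the number, compound 4 is expected to sit near compound 3, with a 1.3-fold higher number from compound 3 to compound 4 (0.12 log units; within the scatter) within the scatter. Compound 4 is therefore estimated at 35 uM, between 12 uM and 95 uM.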

Compound 4, half-maximal toxic concentration: 23.5 uM
Compound 4: the middle estimate sits 1.5-fold (0.17 log units) above what was measured; low and high end bracket the measured number.
By their numbers in this assay, from the lowest: compounds 4, 2 and 3 (each within the scatter of the next). At a limit, above all of these: compound 1.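

On this aromatic carbon of the shared core, carboxy in place of cyano gives a 1.1-fold lower number from compound 3 to compound 4 (0.06 log units; within the scatter) in this assay, and carboxy in place of amino gives a 1.1-fold lower number from compound 2 to compound 4 (0.05 log units; within the scatter), so a third group, one that enters with a hydrogen-bond donor where cyano has none, does not separate from the two already seen. Amino, cyano and carboxy therefore stand within the scatter of each other, and among these four compounds only methyl stands apart, with an at least 4.2-fold lower number from compound 1 to compound 4 (0.62 log units; beyond the scatter). That step starts from a limit, not from a number: the limit of > 100 uM in this assay, at which 1 of the 4 values shown sits.

The compounds shown leave open whether this separation belongs to methyl alone or would also appear with an ethyl group, a methoxy group or a hydroxymethyl group on the same carbon. Also open, on these data alone, is whether a primary amide or a methyl ester at this place would stay within the scatter of compound 2, compound 3 and compound 4, or would stand apart from them as methyl does.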